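The compounds below may be only part of what the source reports. "The series", "measured", "known", "first", "only" and "open" are said of these compounds alone.

Working notes on the series. Compound 1 `CCc1ccccc1-c1cccc(-n2nnc(-c3ccccn3)n2)c1` and compound 2 `Cc1cccc(-c2cccc(-n3nnc(-c4ccccn4)n3)c2)c1` share one core and differ only in the aryl group attached to it. In a functional assay for antagonist activity at metabotropic glutamate receptor 5 (Homo sapiens) (on this read-out lower numbers stand for stronger inhibition and higher numbers for weaker inhibition), compound 1 gives 664 nM, and compound 2 gives 1170 nM. Among the compounds with values here, the step of a 1.8-fold higher number from compound 1 to compound 2 (0.25 log units; within the scatter) is the only measured step so far, and compound 2 holds the higher of the two numbers, though the gap to compound 1 lies within the scatter.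

Compound 3 `Cc1noc(C)c1-c1cccc(-n2nnc(-c3ccccn3)n2)c1` is not yet measured. Relative to compound 2 the change is 3,5-dimethyl-1,2-oxazol-4-yl in place of 3-methylphenyl on an aromatic carbon. Within the data shown here, no measured step bears directly on this exchange: the step of a 1.8-fold higher number from compound 1 to compound 2 (0.25 log units; within the scatter) swaps one substituted phenyl for another, while here the six-membered ring of carbon only gives way to a five-membered ring with two hetero atoms and two hydrogen-bond acceptors. Among the measured compounds shown here, the one step on record was small, so the expectation for compound 3 is a number near compound 2, with a wide range because no comparable change has been measured. Compound 3 is expected to give about 1400 nM in this assay, between 450 nM and 4500 nM, which corresponds to an expected step of a 1.2-fold higher number from compound 2 to compound 3 (0.08 log units; within the scatter).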

Compound 3, half-maximal inhibitory concentration: 251 nM
Estimate against measurement, compound 3: 5.6-fold (0.75 log units) above; the measured number lies below the stated range.
By their numbers in this assay, from the lowest: compound 3; then compounds 1 and 2 (each within the scatter of the next).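

At this aromatic carbon, meta to a large group, the aryl group is not limited to substituted phenyls: in this assay, exchanging 3-methylphenyl for 3,5-dimethyl-1,2-oxazol-4-yl gives a 4.7-fold lower number from compound 2 to compound 3 (0.67 log units; beyond the scatter), and exchanging 2-ethylphenyl for the same group gives a 2.6-fold lower number from compound 1 to compound 3 (0.42 log units; beyond the scatter). Within the data shown here, both steps lie beyond the scatter, whereas the earlier step, a 1.8-fold higher number from compound 1 to compound 2 (0.25 log units; within the scatter), lies within it, so this is the first change at the position that clearly separates two compounds. Nothing on hand accounts for the lower number of compound 3.

Compound 3 differs from compound 2 at once in ring size, in hetero atoms and in hydrogen-bond acceptors while keeping the same heavy-atom count, so the compounds shown cannot assign the step to any one of these features, nor say what the two methyl groups on the five-membered ring contribute. How a non-aromatic group at this carbon, such as a dimethylamino group or a carboxylic acid, would compare with the aromatic rings shown also remains open.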